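This account rests on a few compounds, and the source may have more. Where it says the series, first, only, none or still open, it means among the compounds named here.

Measured compounds in an assay on CHO cells for displacement of a labelled ligand from adenosine receptor A3 (Homo sapiens), tested at 10 uM; a higher number here means more inhibition at the concentration tested (going by the name of the read-out), a lower number less inhibition:
compound 1 `O=C1CC(c2ccccc2)Cc2[nH]c(=O)c(C(=O)c3ccccc3)cc21`: 0%
compound 2 `O=C1CC(c2ccccc2)Cc2[nH]c(=O)c(S(=O)(=O)c3ccccc3)cc21`: 18%
compound 3 `CC(C)(C)C(=O)c1cc2c([nH]c1=O)CCCC2=O`: 0%

Compound 3 stands level with compound 1, the two together giving the lowest numbers of the three, while compound 2 sits a modest distance higher. Among the measured compounds shown here, the only measured step, a number 18 percentage points higher from compound 1 to compound 2 (beyond the scatter), concerns phenylsulfonyl in place of benzoyl and so does not bear on the change at hand. Compound 4 `CC(C)(C)C(=O)c1cc2c([nH]c1=O)CC(c1ccccc1)CC2=O` carries phenyl in place of hydrogen on a saturated ring carbon. Compound 1, which also bears a phenyl on a saturated ring carbon, and compound 3, which lacks it, both show no inhibition, so nothing in this assay points to a step beyond the scatter. The expected step is therefore a number 3 percentage points higher from compound 3 to compound 4 (within the scatter). Compound 4 is estimated at 3%, with a range from 0% to 15%.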

Compound 4, a percentage reported as inhibition, at one concentration (the size of the read-out at that concentration, not a potency): 21%
Beside the measured number, compound 4's estimate is 18 percentage points below it; the whole stated range lies below it.
By their numbers in this assay, from the lowest: compounds 1 and 3 (each within the scatter of the next); then compounds 2 and 4 (each within the scatter of the next).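

On the saturated ring carbon, phenyl in place of hydrogen registers in this assay when the carbonyl carries tert-butyl (a number 21 percentage points higher from compound 3 to compound 4 (beyond the scatter)). With phenyl already present, tert-butyl in place of phenyl on a carbonyl carbon also matters (a number 21 percentage points higher from compound 1 to compound 4 (beyond the scatter)), so the phenyl alone does not give this reading. (Tert-butyl)carbonyl in place of phenylsulfonyl on an aromatic carbon gives no change that can be separated from the scatter (a number 3 percentage points higher from compound 2 to compound 4 (within the scatter)).

Going by these compounds, whether a methyl, an amine or a carboxylic acid on that saturated ring carbon would read like phenyl remains open. No available measurement explains these steps.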